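The source may report more compounds than this note shows. Statements on the series, on what has been measured and on what is new or still open speak of the compounds shown alone.

Working notes on the series. In a functional assay on Bel-7402 cells (Homo sapiens) for inhibition, read by MTT assay, with a stated time of 24 h, tested at 1 ug/mL (a lower number here means less inhibition of growth, a higher number more inhibition of growth at the concentration tested), compound 2 `O=C(CCCCC(S)CCS)Nc1ccccc1` gives 1.32%, and compound 3 `O=C(CCCCC(S)CCS)Nc1ccc(Cl)cc1` gives 0.27%. Within the data shown here, these are the only two numbers so far, and they lie within the scatter of each other. Compound 1 `O=C(CCCCC1CCSS1)Nc1cccc(C(F)(F)F)c1` is reported as "not active" (no number reported), with the trifluoromethyl group present but a different core. Compound 4 `O=C(CCCCC(S)CCS)Nc1cccc(C(F)(F)F)c1` departs from compound 2 by trifluoromethyl in place of hydrogen on an aromatic carbon. Among the measured compounds shown here, the one measured step of this kind is a number 1.1 percentage points lower from compound 2 to compound 3 (within the scatter), chloro in place of hydrogen on an aromatic carbon, and it stays within the scatter. No step beyond the scatter is therefore expected in this assay. The estimated step is a number 0.2 percentage points higher from compound 2 to compound 4 (within the scatter). Compound 4 is expected at 1.5%, within an estimated range of 0% to 10%.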

Compound 4, percent growth inhibition at one concentration: 1.66%
Compound 4: middle estimate off by 0.2 percentage points, on the low side; measured number inside the range.
By their numbers in this assay, from the lowest: compounds 3, 2 and 4 (each within the scatter of the next).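

Trifluoromethyl at this place, meta to a large group, gives a number 0.3 percentage points higher from compound 2 to compound 4 (within the scatter) in this assay, so a group of 4 heavy atoms, like chloro, leaves the number within the scatter. Compound 1 carries the same trifluoromethyl on a different core but has no number, so the step between it and compound 4 cannot be read. Nothing available explains the result. Still open, going by these compounds, is whether an amine or a carboxylic acid on the aromatic ring, or a longer chain in place of the present one, moves the number beyond the scatter.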